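The compounds below may be only part of what the source reports. "The series", "measured", "known", "first", "only" and "open" are said of these compounds alone.

The series was examined in a functional assay on cells for antagonist activity at C-X-C chemokine receptor type 4 (Homo sapiens), read by fluorescence and calcium flux, with stated times of 25 min and 90 s; a lower number here means a stronger inhibitor, a higher number a weaker inhibitor. Compound 1, with the structure `c1ccc(CN(CCCCN(C[C@H]2Cc3ccccc3CN2)[C@H]2CCCc3cccnc32)Cc2ccccc2)cc1`, gives only a limit in this assay, > 16700 nM, and that is the one limit among the three results, (the limit of > 16700 nM in this assay, at which 1 of the 3 values shown sits). Compound 2, with the structure `c1ccc2c(c1)CN[C@@H](CN(CCCCNCC1CCOCC1)[C@H]1CCCc3cccnc31)C2`, gives 52.9 nM, the lowest of the two numbers recorded. Compound 3, with the structure `c1ccc2c(c1)CN[C@@H](CN(Cc1ccc(CNCc3ccncc3)cc1)[C@H]1CCCc3cccnc31)C2`, gives 134 nM, a higher number than that of compound 2 and beyond the scatter of the assay.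

The step of interest leads from compound 2 to compound 4, whose structure is `C(=C/CN(C[C@H]1Cc2ccccc2CN1)[C@H]1CCCc2cccnc21)\CNC1CCOCC1`. Compound 4 has not yet been measured in this assay. The change between the two structures is this: a group of 10 heavy atoms (8 carbon, 1 nitrogen, 1 oxygen; one six-membered non-aromatic ring with 1 hetero atom) in place of a group of 11 heavy atoms (9 carbon, 1 nitrogen, 1 oxygen; one six-membered non-aromatic ring with 1 hetero atom), on a saturated chain carbon bound to an amine nitrogen. The entering 3-((oxan-4-yl)amino)prop-1-en-1-yl group is thus shorter by one heavy atom and carries a double bond outside aromatic rings.

Among the compounds with values here, no measured step in this set shows the effect of such a change, so the expectation rests on compound 2 alone. The step from compound 2 to compound 4 is expected to be modest and toward a weaker inhibitor, a 2.8-fold higher number from compound 2 to compound 4 (0.45 log units; beyond the scatter). Compound 4 is therefore estimated to give 150 nM in this assay, with a range from 40 nM to 600 nM.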

Compound 4, half-maximal inhibitory concentration: 15.5 nM
Compound 4: the middle estimate sits 9.7-fold (0.99 log units) above what was measured; measured number below the stated range.
By their numbers in this assay, from the lowest: compound 4; then compound 2; then compound 3. At a limit, above all of these: compound 1.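

In this assay, the change on a saturated chain carbon bound to an amine nitrogen gives a 3.4-fold lower number from compound 2 to compound 4 (0.53 log units; beyond the scatter), a modest step toward a stronger inhibitor. Within the data shown here, it shows what the earlier compounds could not, as none of them formed a step at this place: the 3-((oxan-4-yl)amino)prop-1-en-1-yl group, a group of 10 heavy atoms with a double bond outside aromatic rings, is accepted here in place of the group of 11 heavy atoms and gives a lower number. Nothing measured here accounts for this step.

In compound 4 the double bond and the shorter chain enter together, so the data cannot assign the step to either one. As far as these compounds go, a saturated propyl chain carrying the same oxan-4-yl amine would separate the two, and it remains open how a piperidine or cyclohexyl ring in place of the oxane ring would fare on the new chain.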